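The source may hold more compounds than are shown below. What is called first, only, known or untested is meant among the compounds shown, and "the series" means these compounds.

In an assay on cells for displacement of a labelled ligand from Orexin/Hypocretin receptor type 1 (Homo sapiens), read by scintillation counting, with stated times of 10 min and 90 min, tested at 10 uM (a higher number here means more inhibition at the concentration tested (going by the name of the read-out), a lower number less inhibition), compound 1 `COC(=O)c1ccc2ccc(C(=O)c3ccc(C(F)(F)F)cc3)c-2cc1` gives -60.5%, while compound 2 `O=C(O)c1ccc2ccc(C(=O)c3ccc(C(F)(F)F)cc3)c-2cc1` gives -81.5%. The change from compound 1 to compound 2 is hydrogen in place of methyl on an oxygen next to a carbonyl group, and the step it made is a number 21 percentage points lower from compound 1 to compound 2 (beyond the scatter). Compound 3 `COC(=O)c1cccc2c(C(=O)c3ccccc3)cc(C(=O)c3ccc(C(F)(F)F)cc3)c-2c1` gives 10.4% in this assay, the highest of the three numbers, well above compound 1 and further still above compound 2. The difference between the core of compound 3 and the core of compound 1 is not broken down here. Compound 4 `O=C(O)c1cccc2c(C(=O)c3ccccc3)cc(C(=O)c3ccc(C(F)(F)F)cc3)c-2c1` has not yet been tested in this assay. It differs from compound 3 by hydrogen in place of methyl on an oxygen next to a carbonyl group, the same change that turned compound 1 into compound 2, at a place described in identical words. Among the measured compounds shown here, with only one earlier example of this change to draw on, the same direction and roughly the same size are expected. Compound 4 is therefore expected to give about -10% in this assay, most likely between -45% and 25%. The expected step is a number 20.4 percentage points lower from compound 3 to compound 4 (beyond the scatter), set beside the earlier step because compound 2 showed a number 21 percentage points lower from compound 1 to compound 2 (beyond the scatter) relative to compound 1.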

Compound 4, a percentage reported as inhibition, at one concentration (the size of the read-out at that concentration, not a potency): 18.3%
Compound 4: middle estimate off by 28.3 percentage points, on the low side; measured number inside the range.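

In this assay, the change from methoxycarbonyl to carboxy on the core of compound 3 gave a number 7.9 percentage points higher from compound 3 to compound 4 (within the scatter), so on this core the swap produced no shift that can be told from the scatter. The same change therefore did not bring a fixed step from one core to the other: the same change on two cores in this assay, a number 21 percentage points lower (beyond the scatter) from compound 1 to compound 2 and a number 7.9 percentage points higher (within the scatter) from compound 3 to compound 4, 28.9 percentage points apart, beyond the scatter of two such steps This shows that the earlier step could not simply be carried over to the second core, but with one pair on each core it does not show which part of the cores makes the difference or what the change would do on a third core.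

The compounds shown leave open how an amide or an ethyl ester would read in place of the methoxycarbonyl or carboxy group on either core. They also leave open whether the two cores would still part ways with a chlorine in place of the trifluoromethyl group.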